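The source may report more compounds than this note shows. Statements on the series, on what has been measured and on what is new or still open speak of the compounds shown alone.

Compound 1 `CN1CCN(c2nc(-c3ccccc3O)nc3c2ncn3C)CC1` gives 36% in an assay on cells for displacement of a labelled ligand from adenosine receptor A2b (Homo sapiens), read by scintillation counting and radioligand binding, with a stated time of 30 min, tested at 10 uM; on this read-out higher numbers stand for more inhibition at the one concentration tested (going by the name of the read-out) and lower numbers for less inhibition.
Compound 2 `Cn1cnc2c(N3CCCCC3)nc(-c3ccccc3Cl)nc21` gives 32.7% in this assay.
Compound 3 `CN1CCN(c2nc(-c3ccc(Cl)c(Cl)c3)nc3c2ncn3C)CC1` gives 28.3% in this assay.

All three compounds share one core and differ in the amine on it and in the aryl group attached to it. Their three numbers lie close together: compound 2 sits within the usual scatter of compound 1 on one side and of compound 3 on the other, so no ordering among them can be claimed. Within the data shown here, the only single-point step among them, a number 7.7 percentage points lower from compound 1 to compound 3 (within the scatter), is also within the scatter.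

Compound 4 `Cn1cnc2c(N3CCCCC3)nc(-c3cc(Cl)ccc3Cl)nc21` is the not yet measured compound. It differs from compound 2 by chloro in place of hydrogen on an aromatic carbon, which, described one bond further out, reads 2-chlorophenyl to 2,5-dichlorophenyl. The step from compound 1 to compound 3 is the only measured one that bears on it, since it also adds chlorine to the aryl ring, and it produced no movement beyond the scatter. On that basis, in this assay a step of a number 0.7 percentage points lower from compound 2 to compound 4 (within the scatter) is expected, that is, no change beyond the scatter. Compound 4 is therefore estimated to give 32%, between 18% and 46%.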

Compound 4, a percentage reported as inhibition, at one concentration (the size of the read-out at that concentration, not a potency): 31%
Compound 4: middle estimate off by 1 percentage points, on the high side, within the range that was stated.
By their numbers in this assay, from the lowest: compounds 3, 4, 2 and 1 (each within the scatter of the next).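

Adding chloro to the ring of compound 2, on the aromatic carbon meta to a large group and para to a chloro group, turns 2-chlorophenyl into 2,5-dichlorophenyl and gives a number 1.7 percentage points lower from compound 2 to compound 4 (within the scatter) in this assay. Unlike the earlier step between compound 1 and compound 3, where the amine stayed the same but a hydroxyl group also left the ring, this change adds one chlorine and removes no heavy atom, so it isolates that atom at this position. On this pair, a second chlorine at this position on a ring that already carries one leaves the read-out within the scatter, and no measurement given here offers an explanation for that.

The compounds shown leave open whether a different group at this position, such as an amine, a carboxylic acid or a longer chain, would move the number beyond the scatter. They also leave open whether the same added chloro would behave alike on a compound with the amine of compound 1, and a reading at a single concentration gives no potency for any of them.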